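A few compounds are considered here, and "the series" means these few. Any claim that something is new, unique, unknown or untested is made for them only; others in the source may bear on it.

Within the data shown here, in a functional assay (aorta) for inhibition, with Rattus norvegicus as the target, with a stated time of 8 days (on this read-out lower numbers stand for stronger inhibition and higher numbers for weaker inhibition), compound 2 (`FC(F)(F)c1cccc(N2CCN(c3ccc(-c4ncns4)nn3)CC2)c1`) gives 70 nM, and this is the only exact number available. Compound 1 (`Cc1nsc(-c2nccc(N3CCN(c4cccc(C(F)(F)F)c4)CC3)n2)n1`), built on a different core, reads > 100 nM, which is a limit of the assay rather than a number. The evidence is therefore thin: the limit of > 100 nM in this assay, at which 1 of the 2 values shown sits. Compound 3 (`Cc1nsc(-c2ccc(N3CCN(c4cccc(C(F)(F)F)c4)CC3)nn2)n1`) keeps the core of compound 2 and changes one place, with methyl in place of hydrogen on an aromatic carbon. The 1,2,4-thiadiazol-5-yl group thus becomes 3-methyl-1,2,4-thiadiazol-5-yl. Among the measured compounds shown here, no measured pair isolates this change, so its effect on this assay has no direct precedent. The expectation is a step that stays within the usual scatter, with a slight lean toward weaker inhibition. That lean rests only on compound 1, which carries the same methylated group and reads > 100 nM, a limit. The expected size of the change is a 1.2-fold higher number from compound 2 to compound 3 (0.08 log units; within the scatter). The estimated value for compound 3 is 85 nM, with an expected range from 30 nM to 240 nM.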

Compound 3, half-maximal inhibitory concentration: 0.3 nM
Beside the measured number, compound 3's estimate is 280-fold (2.45 log units) above it; the measured number lies below the stated range.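

In this assay, a single added methyl on the aromatic carbon between two ring nitrogen atoms brings a 230-fold lower number from compound 2 to compound 3 (2.37 log units; beyond the scatter), so what this position of the five-membered ring carries matters greatly in this read-out. Among these compounds, this is the first pair that isolates the change from 1,2,4-thiadiazol-5-yl to 3-methyl-1,2,4-thiadiazol-5-yl, and what it shows holds so far only for the shared core of this one pair. Compound 1 carries the same methylated group on a different core and gives > 100 nM, which is a limit of the assay, so the whole reading of this change rests on the single pair: the limit of > 100 nM in this assay, at which 1 of the 3 values shown sits.

The compounds shown leave open whether the effect is specific to methyl, or whether an ethyl, a methoxy or an amine at the same place would give a step of similar size. They also leave open whether methyl would have the same effect on the core of compound 1, and why this one small change is so large remains unexplained.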